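Bromo to Cyano on the Sulfonyl Aryl Ring

A few compounds are considered here, and "the series" means these few. Any claim that something is new, unique, unknown or untested is made for them only; others in the source may bear on it.

Compound 1 `O=C1/C(=C/c2cccc(F)c2)CN(S(=O)(=O)c2ccc(O[N+](=O)[O-])cc2)C/C1=C\c1cccc(F)c1` gives 15300 nM in a functional assay on SMMC-7721 cells (Homo sapiens) for cytotoxicity, read by MTT assay, with a stated time of 24 h; a higher number here means a weaker inhibitor, a lower number a stronger inhibitor.
Compound 2 `O=C1/C(=C/c2cccc(F)c2)CN(S(=O)(=O)c2ccc(Br)cc2)C/C1=C\c1cccc(F)c1` gives 11700 nM in this assay.

Within the data shown here, the one step measured so far, bromo in place of nitrooxy on an aromatic carbon, produced a 1.3-fold lower number from compound 1 to compound 2 (0.12 log units; within the scatter). On the numbers shown, compound 2 and compound 1 therefore sit within the scatter of each other, and neither can be set above the other.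

Compound 3 `N#Cc1ccc(S(=O)(=O)N2C/C(=C\c3cccc(F)c3)C(=O)/C(=C/c3cccc(F)c3)C2)cc1` has not yet been measured. It differs from compound 2 by cyano in place of bromo on an aromatic carbon. Among the measured compounds shown here, the only measured step that bears on this change is a 1.3-fold lower number from compound 1 to compound 2 (0.12 log units; within the scatter), which exchanged a different group at the same aromatic carbon and stayed within the scatter. Nothing measured points to a shift beyond the scatter in this assay for this exchange, so the expectation for compound 3 is a step of about a 1.0-fold higher number from compound 2 to compound 3 (0.01 log units; within the scatter), that is, essentially no change in either direction. Compound 3 is accordingly estimated at 12000 nM, with a range from 5000 nM to 30000 nM.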

Compound 3, half-maximal inhibitory concentration: 4500 nM
For compound 3 the middle estimate is 2.7-fold (0.43 log units) above the measured one; measured number outside the range, below it.
By their numbers in this assay, from the lowest: compound 3; then compounds 2 and 1 (each within the scatter of the next).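

In this assay, among these compounds, cyano in place of bromo on this aromatic carbon gives a 2.6-fold lower number from compound 2 to compound 3 (0.41 log units; beyond the scatter) and is the first exchange here to pass beyond the scatter, so the number does respond to the group at this carbon, which the exchange of nitrooxy for bromo alone could not show. Cyano in place of nitrooxy agrees with this, giving a 3.4-fold lower number from compound 1 to compound 3 (0.53 log units; beyond the scatter) as a second modest step beyond the scatter, and compound 3 therefore has the lowest number of the three, while compound 1 and compound 2 remain within the scatter of each other and cannot be ordered. Nothing available accounts for the difference between cyano and the other two groups, so the result stands as an observation without an explanation.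

The compounds shown leave open whether an amine, a carboxylic acid or a methoxy group at this same carbon would lie nearer to cyano or to bromo and nitrooxy. They also leave open whether the gain with cyano would persist on a shared core bearing something other than the two 3-fluorophenyl groups, since all three compounds carry these unchanged.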